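Swapping the ring on the sulfonamide nitrogen

This account rests on a few compounds, and the source may have more. Where it says the series, first, only, none or still open, it means among the compounds named here.

Compound 2 `O=S(=O)(Nc1ccccn1)c1ccc(N/C(S)=N\c2ccnc3cc(C(F)(F)F)ccc23)cc1` shows the highest number of the two measured compounds in a functional assay on LoVo cells (Homo sapiens) for antiproliferative activity, read by sulforhodamine B assay, with a stated time of 48 h (on this read-out higher numbers stand for weaker inhibition and lower numbers for stronger inhibition), giving 87500 nM. Its neighbour compound 1 `NS(=O)(=O)c1ccc(N/C(S)=N\c2ccnc3cc(C(F)(F)F)ccc23)cc1` gives 34500 nM in this assay, so the change a 2.5-fold higher number from compound 1 to compound 2 (0.40 log units; beyond the scatter). Compound 3 `O=S(=O)(Nc1ncccn1)c1ccc(N/C(S)=N\c2ccnc3cc(C(F)(F)F)ccc23)cc1` differs from compound 2 only in that (pyrimidin-2-yl in place of pyridin-2-yl on a sulfonamide nitrogen). Among the measured compounds shown here, no measured step matches this exchange of one ring for another, so the expectation rests on compound 2 alone and is a step of a 1.1-fold lower number from compound 2 to compound 3 (0.04 log units; within the scatter) in this assay. Compound 3 is therefore expected to give about 80000 nM in this assay, within a range from 30000 nM to 200000 nM.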

Compound 3, half-maximal inhibitory concentration: 34700 nM
Compound 3: the middle estimate sits 2.3-fold (0.36 log units) above what was measured, and the stated range covers the measured number.
By their numbers in this assay, from the lowest: compounds 1 and 3 (each within the scatter of the next); then compound 2.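

In this assay the sulfonamide nitrogen tells two similar rings apart: pyrimidin-2-yl in place of pyridin-2-yl gives a 2.5-fold lower number from compound 2 to compound 3 (0.40 log units; beyond the scatter) on this read-out. Against plain hydrogen on the same nitrogen, pyrimidin-2-yl gives a 1.0-fold higher number from compound 1 to compound 3 (0.00 log units; within the scatter) and cannot be told apart, so the rise seen with pyridin-2-yl does not hold for both rings. Nothing available explains this difference between the rings. Still open, as far as these compounds go, is how a non-ring group on this nitrogen, such as methyl or acetyl, would read. Also open, from the compounds shown here alone, is whether a five-membered ring such as thiazol-2-yl would read like pyridin-2-yl or like pyrimidin-2-yl.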